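The source may report more compounds than this note shows. Statements on the series, on what has been measured and on what is new or still open speak of the compounds shown alone.

Working notes on the series. Within the data shown here, compound 1 `COc1ccc(-c2cs/c(=N\NC(=O)c3ccc(O)cc3)n2-c2ccc(OC)cc2OC)cc1` carries a 4-methoxyphenyl group on its core and is one of two compounds measured. In a functional assay on HOP-92 cells (Homo sapiens) for cytotoxicity, read by sulforhodamine B assay, with a stated time of 48 h (on this read-out lower numbers stand for stronger inhibition of growth and higher numbers for weaker inhibition of growth), compound 1 gives 37200 nM, the highest of the two numbers recorded. The other measured compound, compound 2 `O=C(c1ccc(O)cc1)n1nc(-c2c(Cl)cccc2Cl)sc1=S`, has a different core and, in this assay, compound 2 gives 7760 nM; the gap between the two values lies beyond the scatter, with compound 1 the weaker of the pair. Compound 2 differs from compound 1 in more than one place. Its value says nothing direct about the change considered here.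

Compound 3 `COc1ccc(-n2c(-c3ccc(Cl)cc3)cs/c2=N\NC(=O)c2ccc(O)cc2)c(OC)c1` differs from compound 1 by a single change: chloro in place of methoxy on an aromatic carbon. Among the measured compounds shown here, no measured pair shows this change, so the expected step rests only on compound 1 and its value of 37200 nM. The expected step from compound 1 to compound 3 in this assay, a 1.5-fold lower number from compound 1 to compound 3 (0.17 log units; within the scatter), is small and is not expected to exceed the scatter. Compound 3 is estimated at 25000 nM in this assay, with a range from 8000 nM to 80000 nM.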

Compound 3, concentration for total growth inhibition: 64600 nM
Estimate against measurement, compound 3: 2.6-fold (0.41 log units) below; measured number inside the range.
By their numbers in this assay, from the lowest: compound 2; then compounds 1 and 3 (each within the scatter of the next).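

In this assay, the exchange of 4-methoxyphenyl for 4-chlorophenyl gives a 1.7-fold higher number from compound 1 to compound 3 (0.24 log units; within the scatter). Among these compounds, this is the first single-change pair, and it shows that, at this place on the six-membered aromatic ring, para to a large group, methoxy and chloro are not told apart by this read-out, even though the exchange removes a hydrogen-bond acceptor from the count and leaves one heavy atom in place of two. Nothing measured on these compounds offers an explanation for this result, so the pair stands as an observation only.

Methoxy and chloro are the only two groups seen at this position, so it remains open whether an amine, a carboxylic acid or a longer alkoxy chain on the same aromatic carbon would give a number beyond the scatter. One pair in one cell line also leaves open whether chloro in place of methoxy would read the same way at the two methoxy groups elsewhere in compound 1 or on a different core.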